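The compounds below may be only part of what the source reports. "The series", "measured", "known", "first", "only" and "open" are said of these compounds alone.

Working notes on a small set of stilbene-type compounds tested in a functional assay on MCF7 cells (Homo sapiens) for inhibition, read by MTT assay, with a stated time of 2 days; a higher number here means a weaker inhibitor, a lower number a stronger inhibitor. Compound 1 `Nc1cccc(/C=C/c2ccccc2)c1` gives 14 ug/mL. Among the measured compounds shown here, compound 2 `Nc1cccc(/C=C/c2ccccc2O)c1` carries an added hydroxy and gives 24.7 ug/mL; the only single-change step measured so far, a 1.8-fold higher number from compound 1 to compound 2 (0.25 log units; within the scatter), is the hydroxy in place of hydrogen on an aromatic carbon. Compound 3 `COc1ccccc1/C=C/c1cccc(O)c1` gives 24.3 ug/mL, which places it second of the three numbers, within the scatter of compound 2 and within the scatter of compound 1, so no ordering among the three can be claimed.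

Compound 4 `COc1ccccc1/C=C/c1cccc(N)c1` is not yet measured in this assay. It differs from compound 3 by amino in place of hydroxy on an aromatic carbon. For the measured compounds named here, no measured step bears directly on an amino replacing a hydroxy: the step from compound 1 to compound 2 swaps hydrogen for hydroxy on the other ring, and compounds 1 and 3 differ in two places, so their values show only that an amino-bearing and a hydroxy-bearing member of the series sit within the scatter of each other. With every step in the set inside the scatter, no step beyond the scatter is expected from compound 3 to compound 4 in this assay, and the expected step is a 1.2-fold lower number from compound 3 to compound 4 (0.08 log units; within the scatter). Compound 4 is therefore estimated at 20 ug/mL, with a range from 9 ug/mL to 45 ug/mL.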

Compound 4, half-maximal inhibitory concentration: 38.7 ug/mL
Compound 4: middle estimate off by 1.9-fold (0.29 log units), on the low side; low and high end bracket the measured number.
By their numbers in this assay, from the lowest: compounds 1, 3, 2 and 4 (each within the scatter of the next, the first and the last beyond it).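

In this assay, among the compounds shown here, the first direct reading of amino in place of hydroxy on an aromatic carbon, meta to a large group, is a 1.6-fold higher number from compound 3 to compound 4 (0.20 log units; within the scatter), so the two groups cannot be told apart at this position. For the compounds shown here, the methoxy-bearing pair adds two readings: methyl in place of hydrogen on an oxygen on an aromatic ring gives a 1.6-fold higher number from compound 2 to compound 4 (0.20 log units; within the scatter), which also stays inside the scatter, while bringing in the methoxy group gives a 2.8-fold higher number from compound 1 to compound 4 (0.44 log units; beyond the scatter), the only single-place step in the set to pass beyond the scatter, and only modestly. Nothing available here accounts for these numbers.

From the compounds shown here alone, whether a carboxylic acid or a dimethylamino group in place of the amino group of compound 4 would give a step beyond the scatter remains open. Also open, going by these compounds, is whether an ethoxy group or a longer alkoxy chain in place of the methoxy group would carry the number further from that of compound 1 or leave it close to that of compound 4.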